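The compounds below may be only part of what the source reports. "The series", "measured", "known", "first", "only" and "open" are said of these compounds alone.

Measured compounds:
compound 1 `Fc1ccc(C(SCCNC2CCN(Cc3ccc(Cl)cc3)CC2)c2ccc(F)cc2)cc1` gives 39.6 nM
compound 2 `[O-][S+](CCNC1CCN(Cc2ccc(F)cc2)CC1)C(c1ccc(F)cc1)c1ccc(F)cc1` gives 50.6 nM

Both values come from an assay on membranes from striatum (strain Sprague-Dawley) for displacement of a labelled ligand from sodium-dependent dopamine transporter (Rattus norvegicus), read by scintillation counting, with a stated time of 120 min; on this read-out lower numbers stand for stronger inhibition and higher numbers for weaker inhibition. Compound 2 holds the higher of the two numbers, and its nearest neighbour is compound 1, whose number lies within the scatter of it, so the two stand level.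

Compound 3 `[O-][S+](CCNC1CCN(CC(O)Cc2ccccc2)CC1)C(c1ccc(F)cc1)c1ccc(F)cc1` has not been run in this assay. It departs from compound 2 by one change: 1-hydroxy-2-phenylethyl in place of 4-fluorophenyl on a saturated chain carbon bound to an amine nitrogen in a ring. Among the measured compounds shown here, no pair with this difference has been measured, so the expectation rests on the two values alone. The sulfoxide-linked core stays untouched, and both measured compounds sit close together, so a modest move to a higher number, near the edge of the scatter, is the expected outcome. The estimate for compound 3 is 85 nM, with a range from 25 nM to 280 nM. This corresponds to an expected step of a 1.7-fold higher number from compound 2 to compound 3 (0.23 log units; within the scatter).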

Compound 3, inhibition constant: 91.8 nM
Estimate against measurement, compound 3: 1.1-fold (0.03 log units) below, and the stated range covers the measured number.
By their numbers in this assay, from the lowest: compounds 1, 2 and 3 (each within the scatter of the next, the first and the last beyond it).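

In this assay, 1-hydroxy-2-phenylethyl in place of 4-fluorophenyl on a saturated chain carbon bound to an amine nitrogen in a ring gives a 1.8-fold higher number from compound 2 to compound 3 (0.26 log units; within the scatter). This position therefore accepts a group with more heavy atoms, and with a hydrogen-bond donor and acceptor that 4-fluorophenyl lacks, without a step beyond the scatter. No measurement at hand gives a reason for this result.

From the compounds shown here alone, the hydroxyl, the longer chain and the loss of fluorine all change together in this single pair, so their separate contributions remain open; a 3-phenylpropyl group without the hydroxyl would separate the hydroxyl from the other two. Also open, going by these compounds, is how an amine or a carboxylic acid in place of the hydroxyl would read.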